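The source may hold more compounds than are shown below. What is called first, only, known or untested is meant among the compounds shown, and "the series" means these compounds.

Compound 1 `CC1=C(C(=O)OCc2ccccc2)C(c2ccc(-c3ccccc3C)cc2)NC(=O)N1Cc1ccc(-c2nnn[nH]2)cc1` gives 73000 nM in a toxicity assay on RMS13 cells (Homo sapiens) for inhibition, with a stated time of 24 h; a lower number here means a stronger inhibitor of growth, a higher number a weaker inhibitor of growth; its number lies between that of compound 3 `CC1=C(C(=O)OCc2ccccc2)C(c2ccc(-c3ccccc3C)cc2)NC(=S)N1Cc1ccc(-c2nnn[nH]2)cc1`, which gives 68000 nM, and that of compound 2 `CC1=C(C(=O)OCc2ccccc2)C(c2ccc(-c3ccccc3C)cc2)NC(=O)N1CCCCCc1nnn[nH]1`, which gives 100000 nM, all three within the scatter of one another. Among the measured compounds shown here, the only single-point step measured, a 1.4-fold higher number from compound 1 to compound 2 (0.14 log units; within the scatter), alters the group on the ring nitrogen and does not reach beyond the scatter. Compounds 1 and 3 differ at the urea, and their two values likewise lie close together. Compound 4 `CC1=C(C(=O)OCc2ccccc2)C(c2ccc(-c3ccccc3)cc2)NC(=O)N1Cc1ccc(-c2nnn[nH]2)cc1` follows from compound 1 by hydrogen in place of methyl on an aromatic carbon. For the measured compounds named here, no measured step touches this part of the molecule, so the expected step of a 1.0-fold higher number from compound 1 to compound 4 (0.01 log units; within the scatter) is none beyond the scatter. For compound 4 a value of 75000 nM is expected in this assay, with a range of 35000 nM to 160000 nM.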

Compound 4, concentration for 50% growth inhibition: 96000 nM
Compound 4: the middle estimate sits 1.3-fold (0.11 log units) below what was measured; the measured number falls inside the stated range.
By their numbers in this assay, from the lowest: compounds 3, 1, 4 and 2 (each within the scatter of the next).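

Among the compounds shown here, this is the first reading on the aromatic carbon ortho to a large group: in this assay, 2-methylphenyl to phenyl gives a 1.3-fold higher number from compound 1 to compound 4 (0.12 log units; within the scatter), so the methyl can go without a shift beyond the scatter. For the compounds shown here, the single change does not separate the two compounds, and nothing measured here offers an explanation for the result. As far as these compounds go, it remains open whether a methoxy group or an amine on this aromatic carbon would separate from compound 1. The same holds for a carboxylic acid in place of the 1H-tetrazol-5-yl group.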